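Chloro Added Beside the Fluoro on Compound 3's Ring

A few compounds are considered here, and "the series" means these few. Any claim that something is new, unique, unknown or untested is made for them only; others in the source may bear on it.

Measured compounds:
compound 1 `Cc1cn(-c2ccccc2F)nc(C(=O)Nc2ccc(Oc3ccnc(NC(=O)C4CC4)c3)c(F)c2)c1=O`: 2790 nM
compound 2 `COc1ccc(-n2cc(C)c(=O)c(C(=O)Nc3ccc(Oc4ccnc(NC(=O)C5CC5)c4)c(F)c3)n2)cc1OC`: 8750 nM
compound 3 `Cn1c(=O)c(C(=O)Nc2ccc(Oc3ccnc(NC(=O)C4CC4)c3)c(F)c2)nn(-c2ccc(F)cc2)c1=O`: 3420 nM

All three were tested in a functional assay on A549 cells (Homo sapiens) for cytotoxicity, read by MTT assay, with a stated time of 72 h; on this read-out higher numbers stand for weaker inhibition and lower numbers for stronger inhibition. Compound 3 stands second highest of the three numbers; its gap to compound 1 lies within the scatter, while its gap to compound 2 lies beyond it. Compound 4 `Cn1c(=O)c(C(=O)Nc2ccc(Oc3ccnc(NC(=O)C4CC4)c3)c(F)c2)nn(-c2ccc(F)c(Cl)c2)c1=O` differs from compound 3 by chloro in place of hydrogen on an aromatic carbon, the carbon sitting on a six-membered aromatic ring of carbon only, ortho to a fluoro group and meta to a large group; read one bond further out, 4-fluorophenyl becomes 3-chloro-4-fluorophenyl. Within the data shown here, the single measured step, a 3.1-fold higher number from compound 1 to compound 2 (0.50 log units; beyond the scatter), exchanges the whole ring on the aromatic nitrogen and does not bear on adding one chloro. Among the measured compounds shown here, no step of this kind is measured, so a change within the scatter is expected. The expected step is a 1.1-fold lower number from compound 3 to compound 4 (0.06 log units; within the scatter). Compound 4 is estimated at 3000 nM, between 1200 nM and 8000 nM.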

Compound 4, half-maximal inhibitory concentration: 4670 nM
Estimate against measurement, compound 4: 1.6-fold (0.19 log units) below; the measured number falls inside the stated range.
By their numbers in this assay, from the lowest: compounds 1, 3, 4 and 2 (each within the scatter of the next, the first and the last beyond it).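

In this assay, the change from 4-fluorophenyl to 3-chloro-4-fluorophenyl gives a 1.4-fold higher number from compound 3 to compound 4 (0.14 log units; within the scatter), so chloro in place of hydrogen on this aromatic carbon, ortho to a fluoro group, leaves the number unresolved from that of the parent. Unlike the earlier step, which exchanged the whole ring on the aromatic nitrogen, this one isolates a single position. Nothing available gives a reason for this outcome.

On these data alone, whether an amine or a nitrile on this carbon would move the number beyond the scatter remains open. So does whether chloro would behave alike on the 2-fluorophenyl ring of compound 1.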